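A few compounds are considered here, and "the series" means these few. Any claim that something is new, unique, unknown or untested is made for them only; others in the source may bear on it.

Values in a functional assay on SK-MEL-28 cells (Homo sapiens) for inhibition, read by MTT assay, with a stated time of 72 h; on this read-out higher numbers stand for weaker inhibition and lower numbers for stronger inhibition:
Compound 1 `C/C1=C\CC[C@@]2(C)O[C@@H]2[C@H]2OC(=O)[C@@H](CN(C)CCN(C)C)[C@@H]2C[C@H]1O` gives 19000 nM
Compound 2 `C/C1=C\CC[C@@]2(C)O[C@@H]2[C@H]2OC(=O)[C@@H](CN3CCCC3)[C@@H]2C[C@@H]1O` gives 23000 nM
Compound 3 `C[C@]12O[C@@H]1CC[C@@]1(C)O[C@@H]1[C@H]1OC(=O)[C@@H](CN3CCN(c4ccccc4)CC3)[C@@H]1C[C@H]2O` gives 51000 nM

Compound 3 has the highest number of the three, and compound 2 and compound 1 both lie lower by more than the scatter. Compound 4 `C[C@]12O[C@@H]1CC[C@@]1(C)O[C@@H]1[C@H]1OC(=O)[C@@H](CN3CCN(c4ccc(Cl)cc4)CC3)[C@@H]1C[C@H]2O` differs from compound 3 by chloro in place of hydrogen on an aromatic carbon and carries chloro in place of hydrogen on an aromatic carbon, para to a large group. Among the measured compounds shown here, no measured pair isolates a change of this kind, so the expectation is weakly founded. No step beyond the scatter is expected in this assay, with a slight lean towards a lower number. The estimated change is a 1.3-fold lower number from compound 3 to compound 4 (0.11 log units; within the scatter) and stays within the scatter. For compound 4 the estimate is 40000 nM with an expected range of 18000 nM to 90000 nM in this read-out.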

Compound 4, half-maximal inhibitory concentration: 31000 nM
Compound 4: the middle estimate sits 1.3-fold (0.11 log units) above what was measured; low and high end bracket the measured number.
By their numbers in this assay, from the lowest: compounds 1, 2, 4 and 3 (each within the scatter of the next, the first and the last beyond it).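

In this assay, among the compounds shown here, chloro in place of hydrogen on an aromatic carbon, para to a large group, gives a 1.6-fold lower number from compound 3 to compound 4 (0.22 log units; within the scatter) and is the first change that can be read in one place. Phenyl to 4-chlorophenyl therefore leaves the two compounds indistinguishable on this read-out, so this position accepts a chlorine without a step beyond the scatter. Nothing at hand accounts for this result.

Open, going by these compounds, is whether methoxy, an amine or a carboxylic acid in place of chloro would give a step beyond the scatter. Also open, on these data alone, is whether the same chloro step holds on the core of compound 1.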